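Triazole series: ethoxy for methoxy on the second aryl ring

The compounds below may be only part of what the source reports. "The series", "measured", "known", "first", "only" and "open" are said of these compounds alone.

Measured so far: compound 1 `COc1cccc(-c2ncnn2-c2cc(OC)c(OC)c(OC)c2)c1` in a functional assay on MCF7 cells (Homo sapiens) for antiproliferative activity, read by MTT assay, with a stated time of 72 h (on this read-out lower numbers stand for stronger inhibition and higher numbers for weaker inhibition), gives > 10000 nM, a limit of the assay rather than a number. Compound 2 `CCOc1cccc(-c2ncnn2-c2cc(OC)c(OC)c(OC)c2)c1` gives > 10000 nM, again only a limit. Compound 3 `COc1ccccc1-c1ncnn1-c1cc(OC)c(OC)c(OC)c1` gives > 10000 nM, also a limit.

For the measured compounds named here, since all three values sit at the limit of > 10000 nM in this assay, at which 3 of the 3 values shown sit, no step can be sized. From compound 1 to compound 2, the change methyl in place of hydrogen on a saturated chain carbon bound to an oxygen on an aromatic ring yields a step that the two limits leave unreadable from compound 1 to compound 2. The two cores differ by 2-methoxyphenyl in place of 3-methoxyphenyl on an aromatic carbon, and that comparison yields a step that the two limits leave unreadable from compound 1 to compound 3.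

Compound 4 `CCOc1ccccc1-c1ncnn1-c1cc(OC)c(OC)c(OC)c1` carries methyl in place of hydrogen on a saturated chain carbon bound to an oxygen on an aromatic ring, the same change as from compound 1 to compound 2, the place being described in identical words. The step from compound 3 to compound 4 is expected to be a step that the limit leaves unreadable from compound 3 to compound 4, resting on a step that the two limits leave unreadable from compound 1 to compound 2. Compound 4 is expected to give about 20000 nM in this assay, estimated between 8000 nM and 60000 nM, most likely reported as a limit again.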

Compound 4, half-maximal inhibitory concentration: > 10000 nM
Compound 4: only a limit was reported; the forecaster's own chance of this, stated with the estimate: 85%; the middle value does not contradict the limit.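

No step can be read from compound 3 to compound 4, as both values are only limits: the limit of > 10000 nM in this assay, at which 4 of the 4 values shown sit.
The compounds shown leave open how strongly any of them inhibits, and whether methoxy to ethoxy changes that at all.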